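Neopentyl in Place of Isopropyl on a Shared Core

The source may report more compounds than this note shows. Statements on the series, on what has been measured and on what is new or still open speak of the compounds shown alone.

In a functional assay on CHO cells for antagonist activity at adenosine receptor A2b (Homo sapiens), read by 33P incorporation, with a stated time of 20 min, in the presence of a further agent that is not named here (a lower number here means a stronger inhibitor, a higher number a weaker inhibitor), compound 3 `CC(C)n1cc2c(Cl)nc(NC(=O)c3ccc(F)cc3)nc2n1` gives only a limit, > 20000 nM, so its true value is not known. Compound 1 `Cc1ccc(C(=O)Nc2nc(Cl)c3cn(CC(C)(C)C)nc3n2)cc1` likewise gives a limit, > 10000 nM. Compound 2 `CC(C)(C)Cn1cc2c(Cl)nc(NC(=O)c3ccc(C(F)(F)F)cc3)nc2n1` also gives a limit, > 20000 nM. For the measured compounds named here, the only change between measured compounds is a step that the two limits leave unreadable from compound 1 to compound 2; both values sit at the limit of > 10000 nM in this assay, at which 1 of the 3 values shown sits, and (the limit of > 20000 nM in this assay, at which 2 of the 3 values shown sit), so no readable step exists. Compound 4 `CC(C)(C)Cn1cc2c(Cl)nc(NC(=O)c3ccc(F)cc3)nc2n1` differs from compound 3 by neopentyl in place of isopropyl on an aromatic nitrogen. Going by the values given here, no measured step bears on this change, so no direction beyond the scatter can be expected. Compound 4 is therefore expected to give 25000 nM, between 5000 nM and 60000 nM, an expected step that the limit leaves unreadable from compound 3 to compound 4, and most likely again only a limit.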

Compound 4, inhibition constant: > 10000 nM
Compound 4: a limit, no number; the forecaster's own chance of this, stated with the estimate: 85%; the middle value lies beyond the limit too.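

For the compounds shown here, compound 1, compound 2, compound 3 and compound 4 all give only limits in this assay, so no step between them can be read. The compounds shown leave open whether neopentyl versus isopropyl, or fluoro, methyl and trifluoromethyl, make any difference.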